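Permeability of a 4-(tert-butyl)phenyl analogue on the shared core

A few compounds are considered here, and "the series" means these few. Any claim that something is new, unique, unknown or untested is made for them only; others in the source may bear on it.

Compound 1 `CCC(CC)c1ccc2c(NCCCNCc3cc(F)ccc3OC)ccnc2c1` and compound 2 `CCC(CC)c1ccc2c(NCCCNCc3cccc(OC)c3O)ccnc2c1` share one core and were both tested in an ADME assay for permeability, using PAMPA, with a stated time of 30 min, at pH 7.4; a higher number here means that the compound crosses the layer faster, a lower number that the compound crosses the layer more slowly. In that assay compound 1 gives 23 10^-6 cm/s, and compound 2 gives 23 10^-6 cm/s. Within the data shown here, the single step between them, no change at the digits printed from compound 1 to compound 2 (within the scatter), rests on a 2-hydroxy-3-methoxyphenyl in place of 5-fluoro-2-methoxyphenyl on a saturated chain carbon bound to an amine nitrogen. Compound 1 therefore stands level with compound 2 on the numbers shown, with no measured neighbour apart from compound 2.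

Compound 3 `COc1ccc(F)cc1CNCCCNc1ccnc2cc(-c3ccc(C(C)(C)C)cc3)ccc12` differs from compound 1 at another place: 4-(tert-butyl)phenyl in place of pentan-3-yl on an aromatic carbon. No measured step touches this position, so nothing shown bears directly on the change; the only step seen, from compound 1 to compound 2, lay elsewhere and was flat. With the scatter of the method in view, compound 3 is expected to sit near compound 1, with the step from compound 1 to compound 3 estimated as a 1.2-fold lower number from compound 1 to compound 3 (0.06 log units; within the scatter) in this assay. The estimate for compound 3 is 20 10^-6 cm/s, within a range from 8 10^-6 cm/s to 40 10^-6 cm/s.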

Compound 3, apparent permeability: 237 10^-6 cm/s
Compound 3: middle estimate off by 12-fold (1.07 log units), on the low side; measured number above the stated range.
By their numbers in this assay, from the lowest: compounds 1 and 2 (each within the scatter of the next); then compound 3.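

The position on the aromatic carbon, para to a fused ring and meta to a fused ring, proves far from indifferent in this assay: 4-(tert-butyl)phenyl in place of pentan-3-yl gives a 10-fold higher number from compound 1 to compound 3 (1.01 log units; beyond the scatter), beyond the scatter, whereas the earlier change elsewhere in the molecule gave no change at the digits printed from compound 1 to compound 2 (within the scatter) and so said nothing about this site. The change adds one six-membered aromatic ring of carbon only and takes the group from 5 to 10 heavy atoms, with no hydrogen-bond donors or acceptors on either side. No measurement shown gives a reason for the rise.

From the compounds shown here alone, it remains open whether an unsubstituted phenyl or a tert-butyl group alone at this position would give a similar step. A pyridine ring in this place is equally unresolved, as is whether the step would hold with the 2-hydroxy-3-methoxyphenyl group of compound 2.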